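Fluoro on the amide-bearing ring of a weak series

The compounds below may be only part of what the source reports. "The series", "measured", "known", "first", "only" and "open" are said of these compounds alone.

Compound 1 `Cc1cc(=O)n(-c2ccccc2C(F)(F)F)nc1C(=O)Nc1ccc(Oc2ncnc3sccc23)cc1` is the parent here. In a functional assay on MCF7 cells (Homo sapiens) for cytotoxicity, read by MTT assay, with a stated time of 72 h (on this read-out higher numbers stand for weaker inhibition and lower numbers for stronger inhibition), compound 1 gives only a limit of the assay, > 40000 nM. Compound 2 `Cc1cc(=O)n(-c2ccc(F)cc2)nc1C(=O)Nc1ccc(Oc2ncnc3sccc23)cc1` differs from compound 1 in that (2-(trifluoromethyl)phenyl in place of 4-fluorophenyl on an aromatic nitrogen); in this assay compound 2 gives 21000 nM. Compound 3 `Cc1cc(=O)n(-c2ccc(F)c(F)c2)nc1C(=O)Nc1ccc(Oc2ncnc3sccc23)cc1` carries fluoro in place of hydrogen on an aromatic carbon, and in this assay compound 3 gives 16100 nM, so that a 1.3-fold lower number from compound 2 to compound 3 (0.12 log units; within the scatter). Compound 4 `Cc1cc(=O)n(-c2ccccc2C(F)(F)F)nc1C(=O)Nc1ccc(Oc2ncnc3sccc23)c(F)c1` carries fluoro in place of hydrogen on an aromatic carbon. This is the same kind of change as that from compound 2 to compound 3, not the same one: there the new fluoro sits ortho to a fluoro group (1 heavy atom), here ortho to a large group. Compound 4 is expected to show a number no higher from compound 1 to compound 4 (the limit leaves the size open), resting on compound 1 sitting at the limit of > 40000 nM in this assay, at which 1 of the 3 values shown sits, and on the small measured step of a 1.3-fold lower number from compound 2 to compound 3 (0.12 log units; within the scatter). The estimate for compound 4 is 40000 nM, most likely again only a limit.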

Compound 4, half-maximal inhibitory concentration: 13800 nM
Beside the measured number, compound 4's estimate is 2.9-fold (0.46 log units) above it; the measured number lies below the stated range.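

In this assay, fluoro in place of hydrogen on an aromatic carbon gives an at least 2.8-fold lower number from compound 1 to compound 4 (0.46 log units; beyond the scatter), so on the core of compound 1 the change has a readable effect. Compound 1 gives only a limit of the assay, > 40000 nM. Whether the change carries from one core to the other at the same size is not shown: the same change on two cores in this assay, a 1.3-fold lower number (0.12 log units; within the scatter) from compound 2 to compound 3 and an at least 2.8-fold lower number (0.46 log units; beyond the scatter) from compound 1 to compound 4; the limit leaves it open whether they differ

The compounds shown leave open what the same fluoro would give at this aromatic carbon on the core of compound 2, where a direct comparison with compound 4 could be read. Also open, from the compounds shown here alone, is whether a chloro, a methoxy or an amine at that carbon would follow the fluoro step in this assay.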